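The source may report more compounds than this note shows. Statements on the series, on what has been measured and on what is new or still open speak of the compounds shown alone.

Compound 1 `COc1cc(-c2ncnn2-c2ccccc2)cc(OC)c1OC` in a functional assay on MCF7 cells (Homo sapiens) for antiproliferative activity, read by MTT assay, with a stated time of 72 h (a higher number here means a weaker inhibitor, a lower number a stronger inhibitor), gives > 10000 nM, a limit of the assay.
Compound 2 `COc1cc(-c2ncnn2-c2ccc(Cl)c(Cl)c2)cc(OC)c1OC` in this assay gives > 10000 nM, a limit of the assay.
Compound 3 `COc1cc(-c2ncnn2-c2ccc(F)cc2)cc(OC)c1OC` in this assay gives > 10000 nM, a limit of the assay.

Compound 3 thus stands at the same limit as the other two measured compounds; none of the three gives a number. The step that the two limits leave unreadable from compound 1 to compound 2, the step that the two limits leave unreadable from compound 1 to compound 3 and the step that the two limits leave unreadable from compound 2 to compound 3 are all unreadable, since both ends of each sit at the limit (the limit of > 10000 nM in this assay, at which 3 of the 3 values shown sit).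

Compound 4 `COc1cc(-c2ncnn2-c2ccc(Cl)cc2)cc(OC)c1OC` differs from compound 3 in one place: chloro in place of fluoro on an aromatic carbon. The measured steps that bear on this change are the three above, and each of them is unreadable for the same reason, so they give no direction and no size for the exchange of a halogen on the aromatic ring. With every neighbour of compound 4 at the limit, no step beyond the scatter is expected for the step that the limit leaves unreadable from compound 3 to compound 4, and compound 4 is expected to remain at or beyond the same limit.

The estimate for compound 4 in this assay is therefore 20000 nM, with a range from 8000 nM to 60000 nM, most likely reported again only as a limit.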

Compound 4, half-maximal inhibitory concentration: > 10000 nM
Compound 4: only a limit was reported; the forecaster's own chance of this, stated with the estimate: 85%; the middle value lies beyond the limit too.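

Compound 4 in this assay gives > 10000 nM, a limit of the assay. Its steps to compound 1, compound 2 and compound 3 cannot be read, because both ends of each sit at that limit: the limit of > 10000 nM in this assay, at which 4 of the 4 values shown sit.

The compounds shown leave open whether any of these halogen exchanges on the phenyl ring changes the activity at all, and by how much.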